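Chloro to difluoromethyl on the shared core

The source may report more compounds than this note shows. Statements on the series, on what has been measured and on what is new or still open speak of the compounds shown alone.

Three ureas of one core have numbers. Compound 1 `Cc1ccc(NC(=O)N2CCN(c3ncccc3C(F)(F)F)CC2)cc1` gives 556 nM in a functional assay on HEK293 cells for antagonist activity at transient receptor potential cation channel subfamily V member 1 (Rattus norvegicus); a lower number here means a stronger inhibitor, a higher number a weaker inhibitor. For the measured compounds named here, compound 2 `O=C(Nc1ccc(Oc2ccccc2)cc1)N1CCN(c2ncccc2C(F)(F)F)CC1` gives 258 nM, and the single one-place step, a 2.2-fold lower number from compound 1 to compound 2 (0.33 log units; beyond the scatter), is the only measured step in the set. Compound 3 `CC(C)c1ccc(NC(=O)N2CCN(c3ncccc3Cl)CC2)cc1` gives 11.5 nM, the lowest of the three numbers; its gaps to compound 2 and to compound 1 are both well beyond the scatter. Going by the values given here, compound 3 differs from compounds 1 and 2 in two places at once, so no measured step separates the two positions.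

Compound 4 `CC(C)c1ccc(NC(=O)N2CCN(c3ncccc3C(F)F)CC2)cc1` carries difluoromethyl in place of chloro on an aromatic carbon. Among the compounds with values here, no measured step touches this position, and the one measured step concerns the other aromatic ring, so it gives no direct guide. With nothing to point either way, the expected step of a 1.7-fold higher number from compound 3 to compound 4 (0.24 log units; within the scatter) is small, within or near the scatter. Compound 4 is therefore estimated at 20 nM, with a range from 6 nM to 70 nM.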

Compound 4, half-maximal inhibitory concentration: 27.7 nM
For compound 4 the middle estimate is 1.4-fold (0.14 log units) below the measured one; low and high end bracket the measured number.
By their numbers in this assay, from the lowest: compound 3; then compound 4; then compound 2; then compound 1.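

In this assay, this position, on an aromatic carbon of a six-membered aromatic ring with 1 nitrogen and two atoms from the ring nitrogen, now has its first measured step: a 2.4-fold higher number from compound 3 to compound 4 (0.38 log units; beyond the scatter). The step is modest but beyond the scatter, so the position does respond to difluoromethyl in place of chloro, with 3-(difluoromethyl)pyridin-2-yl giving up a little against 3-chloropyridin-2-yl. No measurement at hand bears on what lies behind this step.

Trifluoromethyl at this position stands only in compound 1 and compound 2, which also differ from compound 4 on the other aromatic ring, so its place relative to chloro and difluoromethyl stays open. As far as these compounds go, how a nitrile, a methoxy or a bromo would read at this position also remains open.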